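This account rests on a few compounds, and the source may have more. Where it says the series, first, only, none or still open, it means among the compounds named here.

In an assay on isolated protein for inhibition of Apoptosis regulator Bcl-2 (Homo sapiens), read by fluorescence polarization, with stated times of 5 min and 10 min (on this read-out lower numbers stand for stronger inhibition and higher numbers for weaker inhibition), compound 3, `CC(C)=CCCC1=CC[C@@H](C(=O)Nc2ccc(O)cc2)[C@H](c2ccccc2)C1`, gives > 23000 nM, a figure that is a limit of the assay and not a measured number. Compound 1, `CC(C)=CCCC1=CC[C@@H](C(=O)N(C)C)[C@H](c2ccccc2)C1`, gives in this assay > 23000 nM, again a limit. Compound 2, `COC(=O)CCNC(=O)[C@@H]1CC=C(CCC=C(C)C)C[C@H]1c1ccccc1`, gives in this assay > 23000 nM, also a limit. Because of the limit of > 23000 nM in this assay, at which 3 of the 3 values shown sit, the three steps among these compounds stay unreadable: a step that the two limits leave unreadable from compound 1 to compound 2, a step that the two limits leave unreadable from compound 1 to compound 3 and a step that the two limits leave unreadable from compound 2 to compound 3 each have a size that cannot be drawn from two limits. Compound 4, `CC(C)=CCCC1=CC[C@@H](C(N)=O)[C@H](c2ccccc2)C1`, differs from compound 3 in one place: hydrogen in place of 4-hydroxyphenyl on an amide-type nitrogen. Among the measured compounds shown here, no measured step bears readably on this change; what the three compounds show is that three different substituents on the amide-type nitrogen all left the inhibition too weak for this assay to report a number. Compound 4 is therefore expected to fall at the limit as well, with an estimate of 30000 nM in a range from 15000 nM to 100000 nM. The expected step that the limit leaves unreadable from compound 3 to compound 4 is accordingly none beyond the scatter.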

Compound 4, inhibition constant: > 23000 nM
Compound 4: only a limit was reported (the forecaster's own chance of this, stated with the estimate: 85%); the middle value is on the limit's open side.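

No new step can be read from compound 4 to compound 1, compound 2 or compound 3, because all four stand at a limit of the assay and not at a number: the limit of > 23000 nM in this assay, at which 4 of the 4 values shown sit. The compounds shown leave open how strongly each one actually inhibits, and whether any change on the amide-type nitrogen would give a readable value.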